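The compounds below may be only part of what the source reports. "The series", "measured", "known", "first", "only" and "open" are said of these compounds alone.

An account of one step in a series of anilide-like amides built on a shared core.

Compound 1 `CCC(=O)NCCCc1ccccc1OC` gives 374 nM in an assay for binding affinity to melatonin receptor (Gallus gallus); on this read-out lower numbers stand for stronger inhibition and higher numbers for weaker inhibition. Compound 2 `COc1ccc(CCCNC(C)=O)cc1`, which carries its methoxy group elsewhere on the ring and a shorter acyl group, gives 14000 nM in this assay. Compound 3 `CCC(=O)NCCCCc1ccccc1OC` gives 339 nM in this assay. Compound 3 therefore stands at the low end of the three numbers, but it cannot be separated from compound 1, whose number lies within the scatter of it; only compound 2 stands clearly apart, with a much higher number.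

Compound 4 `CCCCC(=O)NCCCCc1ccccc1OC` has not yet been measured. It differs from compound 3 by ethyl in place of hydrogen on a saturated chain carbon, two bonds along the chain from a carbonyl carbon, so that the propanoyl group of compound 3 becomes a pentanoyl group. Going by the values given here, no step between measured compounds in this set shows what such a lengthening does, and the numbers for compound 1 and compound 3 say only that the tether between ring and amide tolerates one more carbon. For the acyl side the author expects a modest rise in the number, with the step of a 2.4-fold higher number from compound 3 to compound 4 (0.37 log units; beyond the scatter) not certainly beyond the scatter. Compound 4 is estimated at 800 nM, within a range from 250 nM to 3000 nM.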

Compound 4, inhibition constant: 9190 nM
Beside the measured number, compound 4's estimate is 11-fold (1.06 log units) below it; the measured number lies above the stated range.
By their numbers in this assay, from the lowest: compounds 3 and 1 (each within the scatter of the next); then compounds 4 and 2 (each within the scatter of the next).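

In this assay, going by these compounds alone, the acyl side of the amide proves far less forgiving than the earlier compounds could show: ethyl in place of hydrogen on a saturated chain carbon, two bonds along the chain from a carbonyl carbon, brings a 27-fold higher number from compound 3 to compound 4 (1.43 log units; beyond the scatter), a large step beyond the scatter. Within the data shown here, this is the only step in the set that changes the acyl group alone, and it shows that, on the core of compound 3, the number depends strongly on the length of this chain, since the pentanoyl group gives up most of what the propanoyl group holds. Nothing available here bears on why the number rises so steeply.

Among these compounds, the single step leaves open whether the rise sets in gradually, as a butanoyl group would show, or appears only with the pentanoyl group, and whether a branched chain such as isobutyryl or a cyclopropanecarbonyl group would fare any better. It also leaves open whether the same lengthening would cost as much on the one-carbon-shorter tether of compound 1.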